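The source may hold more compounds than are shown below. What is called first, only, known or untested is meant among the compounds shown, and "the series" means these compounds.

Compound 1 `CCC(=O)N(C)c1ccc2[nH]c(-c3n[nH]c4ccccc34)cc2n1` gives 9300 nM in a functional assay on KB cells (Homo sapiens) for antiproliferative activity, read by MTT assay, with a stated time of 72 h; on this read-out lower numbers stand for stronger inhibition and higher numbers for weaker inhibition.
Compound 2 `CN(C(=O)c1ccccc1)c1ccc2[nH]c(-c3n[nH]c4ccccc34)cc2n1` gives 8580 nM in this assay.

Compound 2 and compound 1 sit within the scatter of each other: a 1.1-fold lower number from compound 1 to compound 2 (0.03 log units; within the scatter). Compound 3 `CN(C(=O)c1ccc(F)cc1)c1ccc2[nH]c(-c3n[nH]c4ccccc34)cc2n1` differs from compound 2 by fluoro in place of hydrogen on an aromatic carbon. For the measured compounds named here, no measured step touches a substituent on the phenyl; the single step known, phenyl in place of ethyl on a carbonyl carbon, stayed within the scatter, so no movement beyond the scatter in this assay is expected. Compound 3 is estimated at 8000 nM, range 4000 nM to 16000 nM, which is expected to mean a 1.1-fold lower number from compound 2 to compound 3 (0.03 log units; within the scatter).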

Compound 3, half-maximal inhibitory concentration: 7220 nM
The estimate for compound 3 lay 1.1-fold (0.04 log units) above the measured number, and the stated range covers the measured number.
By their numbers in this assay, from the lowest: compounds 3, 2 and 1 (each within the scatter of the next).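

In this assay, for the compounds shown here, fluoro in place of hydrogen on an aromatic carbon, para to a large group, is the first change on the phenyl itself, and it stays within the scatter: a 1.2-fold lower number from compound 2 to compound 3 (0.07 log units; within the scatter). The larger replacement of ethyl on the carbonyl carbon by 4-fluorophenyl also stays within the scatter: a 1.3-fold lower number from compound 1 to compound 3 (0.11 log units; within the scatter). No evidence at hand bears on this result.

From the compounds shown here alone, whether an amine or a carboxylic acid at this para position would move the number beyond the scatter remains open. The same holds for a longer chain in place of ethyl.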